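From Ethyl to Butyl on the Bromo Compound

The source may report more compounds than this note shows. Statements on the series, on what has been measured and on what is new or still open speak of the compounds shown alone.

All three compounds share one core and differ only in the phenyl group on an oxygen. In a functional assay on HT-29 cells (Homo sapiens) for antiproliferative activity, read by sulforhodamine B assay, with a stated time of 48 h (on this read-out higher numbers stand for weaker inhibition and lower numbers for stronger inhibition), compound 1 (`CCN1CCN(c2ccc(S(=O)(=O)Oc3cccc(F)c3)cc2)C1=O`) gives > 100000 nM, which is a limit of the assay and not a number. Compound 3 (`CCN1CCN(c2ccc(S(=O)(=O)Oc3ccc(OC)cc3)cc2)C1=O`) gives 60000 nM. Compound 2 (`CCN1CCN(c2ccc(S(=O)(=O)Oc3cccc(Br)c3)cc2)C1=O`) gives 3800 nM, the lower of the two true numbers. Changes at this end of the molecule move the read-out a long way. Bromo in place of fluoro gives an at least 26-fold lower number from compound 1 to compound 2 (1.42 log units; beyond the scatter), and 4-methoxyphenyl in place of 3-bromophenyl gives a 16-fold higher number from compound 2 to compound 3 (1.20 log units; beyond the scatter).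

Compound 4 (`CCCCN1CCN(c2ccc(S(=O)(=O)Oc3cccc(Br)c3)cc2)C1=O`) keeps the bromo group of compound 2 and changes the other end. Here ethyl becomes butyl (ethyl in place of hydrogen on a saturated chain carbon, two bonds along the chain from an amide-type nitrogen in a ring). For the measured compounds named here, no measured step touches this chain, since all three measured compounds carry ethyl there. The large steps show only that the series can respond strongly, and they give no direction for this change. The step expected in this assay is a 1.3-fold lower number from compound 2 to compound 4 (0.10 log units; within the scatter), which would lie within the scatter. For compound 4 the estimated value is 3000 nM, with a wide expected range from 600 nM to 15000 nM.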

Compound 4, half-maximal inhibitory concentration: 16000 nM
Compound 4: middle estimate off by 5.3-fold (0.73 log units), on the low side; the measured number lies above the stated range.
By their numbers in this assay, from the lowest: compound 2; then compound 4; then compound 3. At a limit, above all of these: compound 1.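

For the compounds shown here, this is the first measured change at the chain end of the molecule, and it shows that this end also affects the read-out: in this assay, ethyl in place of hydrogen on the chain, which turns the ethyl of compound 2 into the butyl of compound 4, gives a 4.2-fold higher number from compound 2 to compound 4 (0.62 log units; beyond the scatter). The step is modest beside the large ones seen at the phenyl group on the oxygen, but it lies beyond the scatter and points toward weaker inhibition, so on the bromo compound this longer chain is not a neutral change. Nothing shown here accounts for why the read-out moves this way.

With a single step at this position, the compounds shown cannot tell whether inhibition weakens steadily as the chain grows, and methyl, propyl or hexyl there would help to settle that. As far as these compounds go, it also stays open whether a chain ending in an amine or a carboxylic acid would behave like butyl, and whether the same step would appear with the 4-methoxyphenyl group in place of the 3-bromophenyl group.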